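The source may hold more compounds than are shown below. What is called first, only, known or untested is meant among the compounds shown, and "the series" means these compounds.

Compound 1 (`Oc1cccc(-c2cc(-c3ccsc3)cc(-c3ccccc3O)n2)c1`) carries a thiophen-3-yl group on the shared core. In a functional assay on T47D cells (Homo sapiens) for cytotoxicity, read by CCK-8 assay (on this read-out lower numbers stand for stronger inhibition and higher numbers for weaker inhibition), compound 1 gives > 50000 nM, which is a limit of the assay and not a number. On these data alone, compound 1 therefore stands at the limit of > 50000 nM in this assay, at which 1 of the 2 values shown sits, and its true position on the scale is unknown. Compound 2 (`Oc1ccc(-c2cc(-c3ccsc3)cc(-c3cccc(O)c3)n2)cc1`) gives 760 nM in this assay.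

Compound 3 (`Oc1cccc(-c2cc(-c3cccnc3)cc(-c3ccccc3O)n2)c1`) differs from compound 1 at a single place: pyridin-3-yl in place of thiophen-3-yl on an aromatic carbon. This puts pyridin-3-yl in place of thiophen-3-yl, opposite the ring nitrogen. Among the compounds with values here, no measured step covers that exchange. Within the data shown here, the only step available, an at least 65-fold lower number from compound 1 to compound 2 (1.81 log units; beyond the scatter), is large, but it comes from 4-hydroxyphenyl in place of 2-hydroxyphenyl, a change at another place. Compound 3 keeps the 2-hydroxyphenyl group of compound 1, so the gain seen in that step is not expected to carry over, and compound 3 is expected to remain weak in this assay. The expected change, an at least 1.2-fold lower number from compound 1 to compound 3 (0.09 log units; that floor lies within the scatter), is small, and any shift could only be towards a lower number. For compound 3 the estimated value is 40000 nM, with an expected range from 6000 nM to 100000 nM.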

Compound 3, half-maximal inhibitory concentration: 6230 nM
Compound 3: middle estimate off by 6.4-fold (0.81 log units), on the high side; the range from low to high includes it.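

With the 2-hydroxyphenyl group kept in place, the position opposite the ring nitrogen proves able to move the read-out on its own: in this assay, pyridin-3-yl in place of thiophen-3-yl gives an at least 8.0-fold lower number from compound 1 to compound 3 (0.90 log units; beyond the scatter). The earlier step had shown a change only at the hydroxyphenyl group, whereas this one shows that a second place on the shared core also matters and that the 2-hydroxyphenyl group does not by itself keep a compound at the weak end of the scale. The size of the new step is only a floor, because compound 1 is held at a limit of the assay and not at a number: the limit of > 50000 nM in this assay, at which 1 of the 3 values shown sits.

The exchange swaps a five-membered ring carrying sulfur for a six-membered ring carrying nitrogen, so the compounds shown cannot separate the effect of the ring size from that of the hetero atom, and a plain phenyl ring or a carboxylic acid at this place remains an open case. On these data alone, it is also open whether pyridin-3-yl would lower the number in the same way when set on compound 2, which carries the 4-hydroxyphenyl group.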